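From 3-fluorophenyl to 4-ethoxyphenyl on a shared core

The source may report more compounds than this note shows. Statements on the series, on what has been measured and on what is new or still open speak of the compounds shown alone.

Measured so far in a functional assay on MCF7 cells (Homo sapiens) for inhibition, read by sulforhodamine B assay (on this read-out higher numbers stand for weaker inhibition and lower numbers for stronger inhibition), for three compounds:
Compound 1 `CCCc1ccc(NC2=CC(=O)c3nc4n(c3C2=O)[C@H]2OC[C@@H](O)[C@H]2OC4)cc1` gives 4660 nM
Compound 2 `O=C1C=C(Nc2ccccc2F)C(=O)c2c1nc1n2[C@H]2OC[C@@H](O)[C@H]2OC1` gives 3640 nM
Compound 3 `O=C1C=C(Nc2cccc(F)c2)C(=O)c2c1nc1n2[C@H]2OC[C@@H](O)[C@H]2OC1` gives 5500 nM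

Compound 3 stands level with the other two within the scatter, as a 1.2-fold higher number from compound 1 to compound 3 (0.07 log units; within the scatter) and a 1.5-fold higher number from compound 2 to compound 3 (0.18 log units; within the scatter) show. Compound 4 `CCOc1ccc(NC2=CC(=O)c3nc4n(c3C2=O)[C@H]2OC[C@@H](O)[C@H]2OC4)cc1` carries 4-ethoxyphenyl in place of 3-fluorophenyl on an amine nitrogen on the same core. The third exchange at this place, a 1.3-fold lower number from compound 1 to compound 2 (0.11 log units; within the scatter), was just as small. No step beyond the scatter is therefore expected in this assay, and the estimated change is a 1.2-fold lower number from compound 3 to compound 4 (0.09 log units; within the scatter) in size. Compound 4 is estimated at 4500 nM (expected range 2000 nM to 10000 nM).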

Compound 4, half-maximal inhibitory concentration: 1430 nM
Beside the measured number, compound 4's estimate is 3.1-fold (0.50 log units) above it, and the stated range ends above it.
By their numbers in this assay, from the lowest: compound 4; then compounds 2, 1 and 3 (each within the scatter of the next).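

In this assay the group on the amine nitrogen turns out able to move the number: 4-ethoxyphenyl gives a 3.8-fold lower number from compound 3 to compound 4 (0.59 log units; beyond the scatter) and a 2.5-fold lower number from compound 2 to compound 4 (0.41 log units; beyond the scatter) as steps beyond the scatter, which no exchange among compound 1, compound 2 and compound 3 had produced. Ethoxy in place of propyl on an aromatic carbon gives a 3.3-fold lower number from compound 1 to compound 4 (0.51 log units; beyond the scatter) so the step follows the ethoxy group and not merely the presence of a chain on the ring. On these data alone, whether methoxy, a longer alkoxy chain or an amine at that place would go further stays open. No evidence at hand accounts for the step.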